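Chain extension on two lactone cores: cytotoxicity notes

The source may report more compounds than this note shows. Statements on the series, on what has been measured and on what is new or still open speak of the compounds shown alone.

Compound 1 `COc1ccc2cc(CO)oc(=O)c2c1` and compound 2 `COc1ccc2cc(CCCO)oc(=O)c2c1` share one core, while compound 3 `COc1ccc2c(c1)C(=O)OC(CO)C2` and compound 4 `COc1ccc2c(c1)C(=O)OC(CCCO)C2` share another. How the core of compound 3 differs from the core of compound 1 is not broken down here.

In an ADME assay on HaCaT cells (Homo sapiens) for cytotoxicity, read by sulforhodamine B assay, with a stated time of 48 h (on this read-out higher numbers stand for weaker inhibition of growth and lower numbers for stronger inhibition of growth), compound 1 gives 134 ug/mL. Compound 2 in this assay gives 29 ug/mL. The change between them is 2-hydroxyethyl in place of hydroxy on a saturated chain carbon bound to an aromatic carbon, and the step it made was a 4.6-fold lower number from compound 1 to compound 2 (0.66 log units; beyond the scatter).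

For compound 3 only a limit is known in this assay, namely >= 250 ug/mL; this is the limit of >= 250 ug/mL in this assay, at which 1 of the 3 values shown sits, and not a measured number.

Compound 4 carries the same kind of change relative to compound 3, (2-hydroxyethyl in place of hydroxy on a saturated chain carbon bound to a saturated ring carbon). The place is not the same word for word: in the measured pair the change sits on a saturated chain carbon bound to an aromatic carbon, in the new pair on a saturated chain carbon bound to a saturated ring carbon, so it is the same kind of change rather than the same change.

The step from compound 3 to compound 4 in this assay is expected to be an at least 2.2-fold lower number from compound 3 to compound 4 (0.35 log units; beyond the scatter), placed beside the measured step of a 4.6-fold lower number from compound 1 to compound 2 (0.66 log units; beyond the scatter), and it rests on that single instance together with the starting value of compound 3 being only a limit, >= 250 ug/mL. Compound 4 is therefore estimated at about 110 ug/mL, with a likely span from 40 ug/mL to 250 ug/mL.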

Compound 4, concentration for 50% growth inhibition: 130 ug/mL
Beside the measured number, compound 4's estimate is 1.2-fold (0.07 log units) below it; low and high end bracket the measured number.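

In this assay, the change from hydroxymethyl to 3-hydroxypropyl on the core of compound 3 gives an at least 1.9-fold lower number from compound 3 to compound 4 (0.28 log units; that floor lies within the scatter), so this step can be read as consistent with the one on the core of compound 1, although its floor alone does not establish a change beyond the scatter. Carrying the change from one core to the other is thus compatible with the data in direction, on a single pair per core, but its size is not shown to carry over: the same change on two cores in this assay, a 4.6-fold lower number (0.66 log units; beyond the scatter) from compound 1 to compound 2 and an at least 1.9-fold lower number (0.28 log units; that floor lies within the scatter) from compound 3 to compound 4; the limit leaves it open whether they differ. On these data alone, the comparison stays open at one end, where compound 3 has a limit of the assay and not a number: the limit of >= 250 ug/mL in this assay, at which 1 of the 4 values shown sits.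

With only the hydroxymethyl and 3-hydroxypropyl chains shown on each core, the compounds leave open whether a longer chain, such as a 5-hydroxypentyl group, would continue the same trend on either core or whether the two cores would part ways. They also leave open whether the hydroxy group on the chain is needed for the step, which an amine, a carboxylic acid or a methyl ether in its place on both cores would help to settle.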